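The source may report more compounds than this note shows. Statements on the series, on what has been measured and on what is new or still open speak of the compounds shown alone.

Working notes on the series. The shared core carries an amine nitrogen on a double-bonded ring carbon, and the three measured compounds differ only in the group on that nitrogen. Compound 1 `COc1cccc(NC2=CC(=O)c3c(nc4n3[C@H]3OC[C@@H](O)[C@H]3OC4)C2=O)c1` bears 3-methoxyphenyl there; in a functional assay on HeLa cells (Homo sapiens) for inhibition, read by sulforhodamine B assay (on this read-out higher numbers stand for weaker inhibition and lower numbers for stronger inhibition), compound 1 gives > 8000 nM, which is a limit of the assay and not a number. Compound 2 `CCCc1ccc(NC2=CC(=O)c3c(nc4n3[C@H]3OC[C@@H](O)[C@H]3OC4)C2=O)cc1` bears 4-propylphenyl; in this assay compound 2 gives 6030 nM. Among the compounds with values here, the step of an at least 1.3-fold lower number from compound 1 to compound 2 (0.12 log units; that floor lies within the scatter) is the only measured step, and its floor sits inside the scatter. Compound 3 `O=C1C=C(NCc2ccccc2)C(=O)c2c1nc1n2[C@H]2OC[C@@H](O)[C@H]2OC1` bears benzyl; in this assay compound 3 gives > 8000 nM, again a limit of the assay and not a number. Most of what is known here is therefore (the limit of > 8000 nM in this assay, at which 2 of the 3 values shown sit).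

Compound 4 `O=C1C=C(Nc2cccc(Cl)c2)C(=O)c2c1nc1n2[C@H]2OC[C@@H](O)[C@H]2OC1` is the next compound: 3-chlorophenyl in place of benzyl on an amine nitrogen. Within the data shown here, no measured step covers this change directly. The aryl amines of compound 1 and compound 2 both sit at or near the limit, so for compound 4 no step beyond the scatter is expected, with the number more likely near the limit than far below it. The step of an at least 1.1-fold lower number from compound 3 to compound 4 (0.05 log units; that floor lies within the scatter) is the expected size of the change. Compound 4 is estimated at 7000 nM, within the range 3000 nM to 20000 nM.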

Compound 4, half-maximal inhibitory concentration: 6040 nM
The estimate for compound 4 lay 1.2-fold (0.06 log units) above the measured number; the range from low to high includes it.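

Replacing benzyl with 3-chlorophenyl on the amine nitrogen gives an at least 1.3-fold lower number from compound 3 to compound 4 (0.12 log units; that floor lies within the scatter), so this change is not shown to move the number beyond the scatter, and its true size remains unknown. Compound 4 does give a second measured aryl amine: in this assay compound 2 gives 6030 nM and compound 4 gives 6040 nM, and these two printed values nearly coincide even though the groups differ in substituent and in where it sits on the ring. The group on this nitrogen still cannot be ranked across the series because so many values are limits: the limit of > 8000 nM in this assay, at which 2 of the 4 values shown sit.

On these data alone, it remains open whether a morpholine, a carboxylic acid or a longer alkyl chain on the amine nitrogen would bring the number well below these values. As far as these compounds go, it is also open whether any other substituted phenyl group would do so.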